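Benzyl for tert-butyl on the ester oxygen, two cores

The source may report more compounds than this note shows. Statements on the series, on what has been measured and on what is new or still open speak of the compounds shown alone.

Four compounds, two cores. Compound 1 `CC1=C(C(=O)OC(C)(C)C)C(c2ccco2)NC(=S)N1` and compound 2 `CC1=C(C(=O)OCc2ccccc2)C(c2ccco2)NC(=S)N1` share one core; compound 3 `CC1=C(C(=O)OC(C)(C)C)C(c2ccoc2)NC(=O)N1C` and compound 4 `CC1=C(C(=O)OCc2ccccc2)C(c2ccoc2)NC(=O)N1C` share the other. How the core of compound 1 and the core of compound 3 differ is not broken down here.

In an assay on membranes from HEK293 cells for displacement of a labelled ligand from adenosine receptor A2b (Homo sapiens), read by scintillation counting, with a stated time of 30 min, tested at 1 uM (a higher number here means more inhibition at the concentration tested (going by the name of the read-out), a lower number less inhibition), compound 1 gives 9%. Compound 2 gives 41% in this assay. The change between the two is benzyl in place of tert-butyl on an oxygen next to a carbonyl group, and it made a number 32 percentage points higher from compound 1 to compound 2 (beyond the scatter).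

Compound 3 gives 16% in this assay; its value sits within the scatter of compound 1 and beyond the scatter below compound 2.

Compound 4 is not yet measured. It differs from compound 3 by benzyl in place of tert-butyl on an oxygen next to a carbonyl group. The place is worded the same for both pairs, so this is the same change, made twice among these compounds and measured once so far. Going by the values given here, compound 4 is expected to gain in this assay by an estimated a number 24 percentage points higher from compound 3 to compound 4 (beyond the scatter), somewhat less than the earlier step, because a number 32 percentage points higher from compound 1 to compound 2 (beyond the scatter) is the only measured instance of this change and it stands on a different core. Compound 4 is thus expected to give 40%, with the likely range running from 20% to 62%.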

Compound 4, a percentage reported as inhibition, at one concentration (the size of the read-out at that concentration, not a potency): 49%
Compound 4: middle estimate off by 9 percentage points, on the low side; the range from low to high includes it.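

In this assay, benzyl in place of tert-butyl on an oxygen next to a carbonyl group gives a number 33 percentage points higher from compound 3 to compound 4 (beyond the scatter). Set beside the earlier instance, the change carries from the core of compound 1 to the core of compound 3 with no difference in size that can be told apart: the same change on two cores in this assay, a number 32 percentage points higher (beyond the scatter) from compound 1 to compound 2 and a number 33 percentage points higher (beyond the scatter) from compound 3 to compound 4, 1 percentage points apart, within the scatter of two such steps

This supports treating the change as transferable between these two cores only; two pairs say nothing about a third core, and since the read-out is inhibition at one concentration rather than a potency, the matching steps do not show that the gain in potency is the same on both cores, nor do they say why benzyl gives the higher numbers.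

The compounds shown hold only tert-butyl and benzyl on this oxygen, so it stays open whether a plain methyl or ethyl, a longer chain, or a benzyl carrying a chlorine or a methoxy group on its ring would follow the same trend. Going by these compounds, it also stays open which of the differences between the two cores, if any, matters on its own, and whether a chain ending in an amine or a carboxylic acid would still give a step of this size on either core.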